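The compounds below may be only part of what the source reports. "The series", "measured", "known", "first", "only" and "open" are said of these compounds alone.

Compound 1 `CCOC(=O)c1c(-c2ccc(Cl)cc2)cc(-c2ccccc2)nc1N1CCCCC1`: 24%
Compound 2 `CCOC(=O)c1c(-c2ccc(Cl)cc2)cc(-c2ccccc2)nc1Nc1ccc(C)cc1`: 82.4%

In a functional assay on the whole organism (strain Wister albino) for inhibition, with Rattus norvegicus as the target, read by paw edema, with stated times of 1 h and 3 h, at a dose of 50 mg/kg by the intraperitoneal route (a higher number here means more inhibition at the dose given (going by the name of the read-out), a lower number less inhibition), compound 2 stands highest of the two numbers shown, with compound 1 the nearest and lower, beyond the scatter. For the measured compounds named here, the single measured step, a number 58.4 percentage points higher from compound 1 to compound 2 (beyond the scatter), changes the group on the aromatic carbon of the shared core and is large. Compound 3 `CCOC(=O)c1c(-c2ccc(Cl)cc2)cc(-c2ccccc2)nc1Nc1ccc(Cl)cc1` is not yet measured; it differs from compound 2 by chloro in place of methyl on an aromatic carbon. Going by the values given here, no measured step touches this part of the molecule: the only known step replaces the whole amine, and both compound 2 and compound 3 keep the arylamino part that went with the high number. On this basis the expected step of a number 6.4 percentage points lower from compound 2 to compound 3 (within the scatter) is none beyond the scatter. Compound 3 is therefore estimated at 76% in this assay, with a range of 52% to 94%.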

Compound 3, a percentage reported as inhibition, in the whole organism at one dose (the size of the read-out at that dose, not a potency): 31.2%
The estimate for compound 3 lay 44.8 percentage points above the measured number, and the stated range ends above it.
By their numbers in this assay, from the lowest: compounds 1 and 3 (each within the scatter of the next); then compound 2.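

In this assay, the arylamino part alone does not secure a high number: chloro in place of methyl, on an aromatic carbon para to a large group, gives a number 51.2 percentage points lower from compound 2 to compound 3 (beyond the scatter), although only one heavy atom is exchanged for another and the listed donor and acceptor counts stay the same. The other new comparison, with (4-chlorophenyl)amino in place of piperidin-1-yl, gives a number 7.2 percentage points higher from compound 1 to compound 3 (within the scatter), so among these three compounds the large rise over compound 1 appears only with (4-methylphenyl)amino, and compound 3 goes against any rule that arylamino alone carries it. Nothing available here accounts for this difference between methyl and chloro. On these data alone, whether a phenylamino group without a substituent, a (4-methoxyphenyl)amino group or a (4-ethylphenyl)amino group would stand with compound 2 or with compound 3 remains open. As far as these compounds go, how these numbers would compare at other doses also remains open.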